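From phenyl to 1-methyl-1H-pyrazol-5-yl on a shared core

The source may report more compounds than this note shows. Statements on the series, on what has been measured and on what is new or still open speak of the compounds shown alone.

Measured so far in an ADME assay on L02 cells (Homo sapiens) for antiproliferative activity, read by CCK-8 assay, with a stated time of 6 days; a lower number here means a stronger inhibitor, a higher number a weaker inhibitor:
- compound 1 `CCN(c1ccc(C#N)c(Cl)c1)c1cc(-c2ccco2)ccc1C`: "not determined" (no result reported)
- compound 2 `CCN(c1ccc(C#N)c(Cl)c1)c1cc(-c2ccccc2)ccc1C`: > 30000 nM

Compound 2 gives > 30000 nM in this assay, and this reading is a limit of the assay, not a number. Compound 1 has no reported result to set beside it. The record therefore holds only (the limit of > 30000 nM in this assay, at which 1 of the 2 values shown sits), and no single number is available for either compound.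

The next compound is compound 3 `CCN(c1ccc(C#N)c(Cl)c1)c1cc(-c2ccnn2C)ccc1C`, which has not yet been measured. It keeps the core of compound 2 and carries 1-methyl-1H-pyrazol-5-yl in place of phenyl on an aromatic carbon. That carbon is meta to a large group and para to a methyl group.

Among the compounds with values here, no measured pair differs in a single place, so this change has no direct precedent. The expected step of a number no higher from compound 2 to compound 3 (the limit leaves the size open) stays within the usual scatter, with no direction expected, and another limit reading is quite likely. This expectation rests on compound 2 alone, whose reading of > 30000 nM is a limit. Compound 3 is estimated at 30000 nM in this assay, with an expected range from 12000 nM to 60000 nM.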

Compound 3, half-maximal inhibitory concentration: 6230 nM
Beside the measured number, compound 3's estimate is 4.8-fold (0.68 log units) above it; the whole stated range lies above it.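

Placing 1-methyl-1H-pyrazol-5-yl in place of phenyl on this aromatic carbon, meta to a large group and para to a methyl group, gives an at least 4.8-fold lower number from compound 2 to compound 3 (0.68 log units; beyond the scatter) in this assay. This shows that the group on this carbon can move the reading, and in this series compound 3, at 6230 nM, supplies the first single number rather than a limit. The reading for compound 2 is a limit of the assay and not a number, so the full size of the step remains unknown: the limit of > 30000 nM in this assay, at which 1 of the 3 values shown sits.

The compounds shown leave open whether the lower number goes with the two hydrogen-bond acceptors of the entering group, with its five-membered ring or with its methyl group, as this one replacement alters all of these at once. They also leave open how an amine, a carboxylic acid or a longer chain on this same carbon would read in this assay.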